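From Naphthyl to Methoxyphenyl: Expecting Growth Inhibition

This account rests on a few compounds, and the source may have more. Where it says the series, first, only, none or still open, it means among the compounds named here.

Compound 1 `CC(C)(C)c1ccc(CNCCCNS(=O)(=O)c2cc(C(F)(F)F)cc(C(F)(F)F)c2)cc1` — in a functional assay on BXPC-3 cells (Homo sapiens) for inhibition, read by MTT assay, with a stated time of 72 h (a lower number here means a stronger inhibitor of growth, a higher number a weaker inhibitor of growth), compound 1 gives 1400 nM.
Compound 2 `O=S(=O)(NCCCCNCc1ccc(Br)cc1)c1cc(C(F)(F)F)cc(C(F)(F)F)c1` — in this assay compound 2 gives 1700 nM.
Compound 3 `O=S(=O)(NCCCNCc1cccc2ccccc12)c1cc(C(F)(F)F)cc(C(F)(F)F)c1` — in this assay compound 3 gives 2700 nM.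

Compound 3, compound 2 and compound 1 all sit within a span no wider than the scatter of this assay, so none of them can be set apart from the others. For the measured compounds named here, the one single-place step among them, a 1.9-fold higher number from compound 1 to compound 3 (0.29 log units; within the scatter), stays inside that scatter. Compound 4 `COc1cccc(CNCCCNS(=O)(=O)c2cc(C(F)(F)F)cc(C(F)(F)F)c2)c1` differs from compound 3 by 3-methoxyphenyl in place of naphthalen-1-yl on a saturated chain carbon bound to an amine nitrogen. Going by the values given here, only the step from compound 1 to compound 3 touches the same place, and it was small; there is no measured exchange of naphthyl for a methoxy-bearing ring. The expectation is therefore a step of a 1.1-fold higher number from compound 3 to compound 4 (0.05 log units; within the scatter) that does not clearly pass beyond the scatter. Compound 4 is estimated at 3000 nM, with a range from 1200 nM to 8000 nM.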

Compound 4, concentration for 50% growth inhibition: 1700 nM
The estimate for compound 4 lay 1.8-fold (0.25 log units) above the measured number; measured number inside the range.
By their numbers in this assay, from the lowest: compounds 1, 2, 4 and 3 (each within the scatter of the next).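

In this assay the step of a 1.6-fold lower number from compound 3 to compound 4 (0.20 log units; within the scatter) shows that this position accepts 3-methoxyphenyl, with one aromatic ring and one hydrogen-bond acceptor, in place of naphthalen-1-yl without leaving the scatter. The steps of a 1.2-fold higher number from compound 1 to compound 4 (0.08 log units; within the scatter) and no change at the digits printed from compound 2 to compound 4 (within the scatter) also stay within it, so compound 4 cannot be set apart from any earlier compound. Nothing available explains why these groups read alike. The compounds shown leave open whether a carboxylic acid or a primary amine on the ring at this place would carry the number beyond the scatter.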